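The source may hold more compounds than are shown below. What is called first, only, known or untested is meant among the compounds shown, and "the series" means these compounds.

Measured in a functional assay on CHO-K1 cells for antagonist activity at adenosine receptor A1 (Homo sapiens), read by a beta-galactosidase reporter and cAMP accumulation, with stated times of 15 min and 6 h; a higher number here means a weaker inhibitor, a lower number a stronger inhibitor:
compound 1 `CCc1ccc(-c2nc(N)c3cc(Cc4ccccc4)sc3n2)o1` — 223 nM
compound 2 `N#Cc1cccc(-c2nc(N)c3cc(Cc4ccccc4F)sc3n2)c1` — < 16 nM, which is a limit of the assay rather than a number the limit of < 16 nM in this assay, at which 1 of the 2 values shown sits.

Going by the values given here, compound 1 therefore stands as the only compound here with a measured number; the other value is a limit. Compound 3 `Nc1nc(-c2cccnc2)nc2sc(Cc3ccccc3)cc12` differs from compound 1 in one place: pyridin-3-yl in place of 5-ethylfuran-2-yl on an aromatic carbon. Among the compounds with values here, no measured pair isolates this change, so its size is open. The step from compound 1 to compound 3 is expected to be small, a 1.5-fold lower number from compound 1 to compound 3 (0.17 log units; within the scatter), most likely within the usual scatter. Compound 3 is estimated at 150 nM, with a range from 40 nM to 600 nM.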

Compound 3, inhibition constant: 1420 nM
Compound 3: the middle estimate sits 9.5-fold (0.98 log units) below what was measured; the measured number lies above the stated range.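

On the aromatic carbon between two ring nitrogen atoms, the group clearly counts in this assay: pyridin-3-yl in place of 5-ethylfuran-2-yl gives a 6.4-fold higher number from compound 1 to compound 3 (0.80 log units; beyond the scatter) on an otherwise unchanged core. These two aromatic rings, each with one hetero atom and one hydrogen-bond acceptor, are therefore not interchangeable here. Nothing measured here explains the direction or size of this step.

Going by these compounds, it remains open whether the ethyl group or the furan ring itself accounts for the difference. Plain furan-2-yl, 5-methylfuran-2-yl or phenyl at this position could help separate the two.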